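Aryl swap on a shared core: cytotoxicity notes

The source may report more compounds than this note shows. Statements on the series, on what has been measured and on what is new or still open speak of the compounds shown alone.

Measured in a functional assay on HT-1080 cells (Homo sapiens) for cytotoxicity, read by MTT assay, with a stated time of 72 h; a lower number here means a stronger inhibitor, a higher number a weaker inhibitor:
- compound 1 `COc1cccc(/C=C2\CCC/C(=C\c3ccc(Br)cc3)C2=O)c1OC`: 13700 nM
- compound 2 `COc1ccccc1/C=C1\CCC/C(=C\c2cccc(OC)c2OC)C1=O`: 14100 nM
- compound 3 `COc1ccc(/C=C2\CCC/C(=C\c3ccc(Br)cc3)C2=O)cc1OC`: 4300 nM

Compound 3 gives the lowest number of the three; its gaps to compound 1 and compound 2 lie beyond the scatter. Compound 1 and compound 2 differ by 2-methoxyphenyl in place of 4-bromophenyl on a double-bonded chain carbon bound to a double-bonded ring carbon and the step is a 1.0-fold higher number from compound 1 to compound 2 (0.01 log units; within the scatter), within the scatter; the two values cannot be ordered.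

Compound 3 and compound 1 share the same atoms joined differently; the difference between the two cores is not broken down here.

Compound 4 `COc1ccccc1/C=C1\CCC/C(=C\c2ccc(OC)c(OC)c2)C1=O` has not been measured. It derives from compound 3 by 2-methoxyphenyl in place of 4-bromophenyl on a double-bonded chain carbon bound to a double-bonded ring carbon, the same change, at the same place, as from compound 1 to compound 2, and that earlier step was a 1.0-fold higher number from compound 1 to compound 2 (0.01 log units; within the scatter). Going by the values given here, on the core of compound 3 the change is therefore expected to give a step of about no change at the digits printed from compound 3 to compound 4 (within the scatter), with only one earlier pair to rest on. Compound 4 is expected to give 4300 nM in this assay, plausibly between 2000 nM and 9500 nM.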

Compound 4, half-maximal inhibitory concentration: 8100 nM
Estimate against measurement, compound 4: 1.9-fold (0.28 log units) below; low and high end bracket the measured number.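

In this assay, 2-methoxyphenyl in place of 4-bromophenyl on a double-bonded chain carbon bound to a double-bonded ring carbon gives a 1.9-fold higher number from compound 3 to compound 4 (0.28 log units; within the scatter), so the two values cannot be ordered. Set beside the earlier step, the change reads alike on both cores: the same change on two cores in this assay, a 1.0-fold higher number (0.01 log units; within the scatter) from compound 1 to compound 2 and a 1.9-fold higher number (0.28 log units; within the scatter) from compound 3 to compound 4, 1.8-fold (0.26 log units) apart, within the scatter of two such steps. Going by these compounds alone, this shows that, on these two cores, the change carries over with neither the steps nor the gap between them beyond the scatter, but with only two pairs it does not show that the change would be neutral on any other core or in any other assay.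

The compounds shown leave open whether an amine, a carboxylic acid or a longer chain at this same place would give a step beyond the scatter. Also open, on these data alone, is whether the change would read alike on a core carrying a nitrile or a trifluoromethyl group.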